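Fluorine removal on the diaryl acyl guanidine side chain

The source may hold more compounds than are shown below. What is called first, only, known or untested is meant among the compounds shown, and "the series" means these compounds.

Measured compounds:
compound 1 `N=C(NCCCc1c[nH]cn1)NC(=O)CC(c1ccccc1)c1ccccc1` 28.2 nM
compound 2 `N=C(NCCCc1c[nH]cn1)NC(=O)C(c1ccccc1)c1ccccc1` 1050 nM
compound 3 `N=C(NCCCc1c[nH]cn1)NC(=O)CC(c1ccc(F)cc1)c1ccc(F)cc1` 204 nM

The series shares one core carrying an imidazole-propyl guanidine, acylated with a diaryl-substituted acid. In a functional assay on cardiac atrium for agonist activity at histamine H2 receptor (Cavia porcellus) (a higher number here means that more compound is needed for the effect, a lower number that less compound is needed), compound 1 gives 28.2 nM, compound 2 gives 1050 nM and compound 3 gives 204 nM.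

Compound 3 stands second highest of the three numbers. Its nearest neighbour is compound 2, whose number is higher than that of compound 3 by a margin beyond the scatter; compound 1 lies furthest away, with a number lower than that of compound 3, again beyond the scatter. Compound 3 and compound 1 differ only in the two fluoro groups, so the gap between them is what the change below is read against.

Compound 4 `N=C(NCCCc1c[nH]cn1)NC(=O)CC(c1ccccc1)c1ccc(F)cc1` has not been measured. From compound 3 it differs by hydrogen in place of fluoro on an aromatic carbon, leaving one 4-fluorophenyl group in place. Among the measured compounds shown here, no step between measured compounds covers this single change; it sits between compound 3 and compound 1.

In this assay compound 4 is expected to give 76 nM, range 30 nM to 200 nM, an expected step of a 2.7-fold lower number from compound 3 to compound 4 (0.43 log units; beyond the scatter) toward a lower number, probably beyond the scatter, because compound 1 with both fluoro groups absent gives 28.2 nM.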

Compound 4, half-maximal effective concentration: 55 nM
Estimate against measurement, compound 4: 1.4-fold (0.14 log units) above, and the stated range covers the measured number.
By their numbers in this assay, from the lowest: compounds 1 and 4 (each within the scatter of the next); then compound 3; then compound 2.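

In this assay the change from 4-fluorophenyl to phenyl on one aryl group, with the other 4-fluorophenyl group kept, gives a 3.7-fold lower number from compound 3 to compound 4 (0.57 log units; beyond the scatter) and so resolves a single fluoro change beyond the scatter. The earlier compounds shown here could not show this, since compound 3 and compound 1 differ in two places. The remaining change, a 2.0-fold higher number from compound 1 to compound 4 (0.29 log units; within the scatter) stays within the scatter, so compound 4 and compound 1 cannot be told apart here, and of the two fluoro steps in this short sequence only the one from compound 3 is resolved; no data shown bear on why the change reads this way.

The compounds shown carry only fluoro or hydrogen at this place, so whether chloro, methyl or methoxy on the aromatic ring would read the same way stays open. Also open, as far as these compounds go, is whether a longer acyl chain carrying the same two aryl groups would keep the same response to fluoro.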